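The source may report more compounds than this note shows. Statements on the series, on what has been measured and on what is new or still open speak of the compounds shown alone.

Measured compounds:
compound 1, `O=C(O)CCCCCOc1cc(-c2ccccc2Cl)cc(-c2ccccc2)n1`, 200 nM
compound 2, `O=C(O)CCCCCOc1cc(-c2ccccc2)cc(-c2ccc(F)cc2)n1`, 30 nM
compound 3, `O=C(O)CCCCOc1cc(-c2ccccc2)cc(-c2ccccc2)n1`, 50 nM

In an assay on cell membranes from spleen (Cavia porcellus) for binding affinity to leukotriene B4 receptor 1 (Homo sapiens) (on this read-out higher numbers stand for weaker inhibition and lower numbers for stronger inhibition), compound 3 gives 50 nM, the second highest of the three numbers. Compound 2 at 30 nM lies within the scatter of it. Compound 1 at 200 nM sits at a higher number, beyond the scatter. No two of these compounds differ in one place, so no single-change step among them is available.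

Compound 4, `N#CCCCCCOc1cc(-c2ccccc2)cc(-c2ccccc2)n1`, differs from compound 3 by cyanomethyl in place of carboxy on a saturated chain carbon, four bonds along the chain from an oxygen on an aromatic ring. Among the measured compounds shown here, no measured pair covers this change, so nothing sets its size. The expectation is a step toward higher numbers, beyond the scatter, from compound 3 to compound 4 of a 10-fold higher number from compound 3 to compound 4 (1.00 log units; beyond the scatter). For compound 4 the estimate in this assay is 500 nM, with a range from 100 nM to 3000 nM.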

Compound 4, half-maximal inhibitory concentration: 700 nM
Compound 4: the middle estimate sits 1.4-fold (0.15 log units) below what was measured; the range from low to high includes it.
By their numbers in this assay, from the lowest: compounds 2 and 3 (each within the scatter of the next); then compound 1; then compound 4.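

In this assay, among the compounds shown here, cyanomethyl in place of carboxy on a saturated chain carbon, four bonds along the chain from an oxygen on an aromatic ring, gives a 14-fold higher number from compound 3 to compound 4 (1.15 log units; beyond the scatter), the first single-change step. At this position, the carboxy group cannot be exchanged for cyanomethyl without a large move toward weaker inhibition. No supporting evidence bears on why the number rises.

As far as these compounds go, whether a primary amide or a tetrazole at this position would stay close to compound 3 remains open. From the compounds shown here alone, the effect of a longer chain alone, with the rest of compound 3 unchanged, also remains open.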